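The source may hold more compounds than are shown below. What is called first, only, known or untested is meant among the compounds shown, and "the series" means these compounds.

Of the compounds shown here, two sharing one core have been measured in a functional assay on SK-BR-3 cells (Homo sapiens) for antiproliferative activity, with a stated time of 48 h; on this read-out higher numbers stand for an effect only at larger amounts of compound and lower numbers for an effect already at smaller amounts. There, compound 1 (`O=C(CCCCCCC(=O)Nc1ccc(Cl)cc1)NO`) gives 2300 nM and compound 2 (`O=C(CCCCCCC(=O)Nc1ccc(I)cc1)NO`) gives 1100 nM, so compound 2 holds the lower of the two numbers. Compound 3 (`N#Cc1ccc(NC(=O)CCCCCCC(=O)NO)cc1`) keeps the same core and differs from compound 2 in one group: cyano in place of iodo on an aromatic carbon. This is cyano in place of iodo on an aromatic carbon, para to a large group.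

Going by the values given here, only one measured step bears on this change, because it concerns a swap of groups on an aromatic carbon: a 2.1-fold lower number from compound 1 to compound 2 (0.32 log units; beyond the scatter). That step is modest, though beyond the scatter. Among the compounds with values here, it relates chloro to iodo only, and no cyano compound has yet been measured, so it is a loose guide. A similarly small move in this assay is therefore expected, towards a higher number and back in the direction of compound 1. The expected change is a 1.6-fold higher number from compound 2 to compound 3 (0.21 log units; within the scatter), which would stay within the scatter. For compound 3 the estimated value is 1800 nM, with an expected range from 800 nM to 4000 nM.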

Compound 3, half-maximal effective concentration: 8800 nM
Compound 3: the middle estimate sits 4.9-fold (0.69 log units) below what was measured, and the stated range ends below it.
By their numbers in this assay, from the lowest: compound 2; then compound 1; then compound 3.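

In this assay, the swap between chloro and iodo had shown only a small shift at this aromatic carbon, para to a large group, with a 2.1-fold lower number from compound 1 to compound 2 (0.32 log units; beyond the scatter) on record. Cyano in place of iodo shows that this position can respond much more strongly, giving an 8.0-fold higher number from compound 2 to compound 3 (0.90 log units; beyond the scatter) in the same assay. Cyano in place of chloro gives a 3.8-fold higher number from compound 1 to compound 3 (0.58 log units; beyond the scatter) as well, so compound 3 stands apart from both halogen-bearing compounds, and nothing measured here accounts for the difference between cyano and the two halogens.

The compounds shown leave open whether other groups on this carbon, such as methoxy, an amine or a carboxylic acid, would give numbers close to those of compound 1 and compound 2 or close to that of compound 3. They also leave open whether fluoro or bromo would stay close to chloro and iodo, and so whether the large step belongs to cyano alone or is shared by other replacements for a halogen at this place.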